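This account rests on a few compounds, and the source may have more. Where it says the series, first, only, none or still open, it means among the compounds named here.

In a physicochemical assay for solubility, in phosphate buffer, at pH 7.4 (on this read-out lower numbers stand for lower solubility and higher numbers for higher solubility), compound 1 `N#CC1CCN(c2nccnc2OC2CN(c3ccc4ccccc4n3)C2)CC1` gives 66000 nM and compound 2 `NC(=O)C1CCN(c2nccnc2OC2CN(c3ccc4ccccc4n3)C2)CC1` gives 14000 nM. Compound 3 `N#Cc1ccc(-c2nccnc2OC2CN(c3ccc4ccccc4n3)C2)cc1` gives < 1000 nM, which is a limit of the assay and not a number. Among the measured compounds shown here, it is the only compound placed this way: the limit of < 1000 nM in this assay, at which 1 of the 3 values shown sits. Its true position is therefore known only from one side.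

Compound 4 `c1ccc2nc(N3CC(Oc4nccnc4-c4ccncc4)C3)ccc2c1` carries pyridin-4-yl in place of 4-cyanophenyl on an aromatic carbon.

For the measured compounds named here, none of the measured steps exchanges one aromatic ring for another, so the evidence is indirect. The closest steps are an at least 66-fold lower number from compound 1 to compound 3 (1.81 log units; beyond the scatter) and an at least 14-fold lower number from compound 2 to compound 3 (1.14 log units; beyond the scatter), both large, and both replace a substituted piperidine with 4-cyanophenyl. Compound 4 keeps a six-membered aromatic ring on that carbon, so neither large step is expected to reverse in full. The change on the saturated ring, a 4.7-fold lower number from compound 1 to compound 2 (0.67 log units; beyond the scatter), is smaller and lies elsewhere in the molecule, so it adds little here.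

A small to modest rise is expected, and a second report at the limit remains possible. The expected step is an at least 2.0-fold higher number from compound 3 to compound 4 (0.30 log units; that floor lies within the scatter). For compound 4 the estimated value is 2000 nM, with an expected range of 500 nM to 12000 nM.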

Compound 4, solubility: 56000 nM
Compound 4: the middle estimate sits 28-fold (1.45 log units) below what was measured; the whole stated range lies below it.
By their numbers in this assay, from the lowest: compound 2; then compounds 4 and 1 (each within the scatter of the next). At a limit, below all of these: compound 3.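

At this position, on an aromatic carbon of a six-membered aromatic ring with 2 nitrogen, aromatic groups do not all behave alike in this assay: pyridin-4-yl in place of 4-cyanophenyl gives an at least 56-fold higher number from compound 3 to compound 4 (1.74 log units; beyond the scatter), so the low read-out of compound 3 cannot be extended to every six-membered aromatic ring on this carbon. Pyridin-4-yl also stands level with 4-cyanopiperidin-1-yl, with a 1.2-fold lower number from compound 1 to compound 4 (0.07 log units; within the scatter), and clear of 4-carbamoylpiperidin-1-yl, with a 4.0-fold higher number from compound 2 to compound 4 (0.60 log units; beyond the scatter), so a saturated ring on this carbon is not required for a read-out in the range of compound 1. The size of the step from compound 3 is only a floor, because compound 3 stands at a limit of the assay: the limit of < 1000 nM in this assay, at which 1 of the 4 values shown sits.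

The change from compound 3 to compound 4 swaps the carbon-only ring for one with a ring nitrogen and removes the nitrile in the same step, and the compounds shown do not separate these two parts. Unsubstituted phenyl on this carbon would separate them, and pyridin-3-yl would show whether the place of the ring nitrogen matters.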